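Adding one hydroxy to compound 2

The source may report more compounds than this note shows. Statements on the series, on what has been measured and on what is new or still open speak of the compounds shown alone.

Measured so far in an ADME assay on MDCK cells (Canis lupus familiaris) for cytotoxicity (a lower number here means that less compound is tolerated, a higher number that more compound is tolerated), for two compounds:
Compound 1 `O=[N+]([O-])C1=CNc2nc(C(F)(F)F)nn2C1c1c(O)cc(O)cc1O` gives 838000 nM
Compound 2 `O=[N+]([O-])C1=CNc2nc(-c3ccco3)nn2C1c1ccc(O)cc1O` gives 119000 nM

Compound 2 holds the lower of the two numbers, and compound 1 stands higher by a gap beyond the scatter. The two differ in more than one place, so no single change has yet been measured. Compound 3 (`O=[N+]([O-])C1=CNc2nc(-c3ccco3)nn2C1c1c(O)cc(O)cc1O`) arises from compound 2 through one change (hydroxy in place of hydrogen on an aromatic carbon): hydroxy in place of hydrogen on an aromatic carbon, ortho to a large group and meta to two hydroxy groups. A small upward step is expected, possibly none beyond the scatter. Among the compounds with values here, the only guide is that compound 1, which also carries this hydroxy, gives 838000 nM in this assay while differing elsewhere too. The expected step is a 1.6-fold higher number from compound 2 to compound 3 (0.20 log units; within the scatter) and would be modest. The estimated value for compound 3 is 190000 nM (expected range 80000 nM to 500000 nM).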

Compound 3, half-maximal cytotoxic concentration: 280000 nM
Estimate against measurement, compound 3: 1.5-fold (0.17 log units) below, within the range that was stated.
By their numbers in this assay, from the lowest: compound 2; then compound 3; then compound 1.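

In this assay, the added hydroxy now has a measured effect of its own: a 2.4-fold higher number from compound 2 to compound 3 (0.37 log units; beyond the scatter) with furan-2-yl held fixed, a modest step beyond the scatter toward more compound being tolerated. Within the data shown here, the change at the other place can also be read for the first time, as furan-2-yl in place of trifluoromethyl gives a 3.0-fold lower number from compound 1 to compound 3 (0.48 log units; beyond the scatter) with the hydroxy-bearing ring unchanged. Nothing available accounts for either step.

As far as these compounds go, whether a methoxy or an amine at the hydroxy's place would move the number in the same way remains open, as does whether the hydroxy gives a similar step alongside trifluoromethyl. Each change is shown only once, so neither step can yet be read as a general trend.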